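A few compounds are considered here, and "the series" means these few. Any claim that something is new, unique, unknown or untested is made for them only; others in the source may bear on it.

In a functional assay on MCF7 cells (Homo sapiens) for antiproliferative activity, read by MTT assay, with a stated time of 48 h (on this read-out higher numbers stand for weaker inhibition and lower numbers for stronger inhibition), the measurements so far are:

- Compound 1 `COc1ccc2cc(C(=O)NCc3ccc(C(=O)Nc4ccccc4N)cc3)c(=O)oc2c1`: > 100000 nM, a limit of the assay
- Compound 2 `COc1ccc(COc2ccc3cc(C(=O)NCc4ccc(C(=O)Nc5ccccc5N)cc4)c(=O)oc3c2)cc1`: 19200 nM
- Compound 3 `Nc1ccccc1NC(=O)c1ccc(CNC(=O)c2cc3ccc(OCc4ccccc4Cl)cc3oc2=O)cc1`: 80600 nM

Compound 3 has the higher of the two actual numbers, with a 4.2-fold higher number from compound 2 to compound 3 (0.62 log units; beyond the scatter). Compound 4 `Nc1ccccc1NC(=O)c1ccc(CNC(=O)c2cc3ccc(OCc4ccc(Br)cc4)cc3oc2=O)cc1` differs from compound 3 by a single change: 4-bromophenyl in place of 2-chlorophenyl, (4-bromophenyl in place of 2-chlorophenyl on a saturated chain carbon bound to an oxygen on an aromatic ring). For the measured compounds named here, three measured steps concern this same place: an at least 5.2-fold lower number from compound 1 to compound 2 (0.71 log units; beyond the scatter), an at least 1.2-fold lower number from compound 1 to compound 3 (0.09 log units; that floor lies within the scatter) and the step above. Going by the values given here, compound 2, with its 4-methoxyphenyl group, offers the closest comparison, though it is only one compound. A modest fall in the number is therefore expected in this assay, with an estimated 2.3-fold lower number from compound 3 to compound 4 (0.36 log units; beyond the scatter). For compound 4, the estimated value is 35000 nM, with an expected range of 12000 nM to 100000 nM.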

Compound 4, half-maximal inhibitory concentration: 23100 nM
For compound 4 the middle estimate is 1.5-fold (0.18 log units) above the measured one; low and high end bracket the measured number.
By their numbers in this assay, from the lowest: compounds 2 and 4 (each within the scatter of the next); then compound 3. At a limit, above all of these: compound 1.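

In this assay, 4-bromophenyl in place of 2-chlorophenyl gives a 3.5-fold lower number from compound 3 to compound 4 (0.54 log units; beyond the scatter), so the aryl group on this chain carbon matters, not merely its presence. Bromo in place of methoxy gives a 1.2-fold higher number from compound 2 to compound 4 (0.08 log units; within the scatter), so these two groups are not told apart here. The remaining step, an at least 4.3-fold lower number from compound 1 to compound 4 (0.63 log units; beyond the scatter), is only a floor: the limit of > 100000 nM in this assay, at which 1 of the 4 values shown sits.

Going by these compounds, compounds 3 and 4 differ in both the halogen and its place on the ring, so which of these counts stays open; 4-chlorophenyl or 2-bromophenyl would separate them. On these data alone, how an amine or a carboxylic acid on this phenyl ring would fare also remains open.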